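The compounds below may be only part of what the source reports. "The series", "measured", "known", "first", "only" and "open" are said of these compounds alone.

Measured in an ADME assay on microsomes from liver (Mus musculus) for metabolic stability, read by LC-MS, using NADPH, with a stated time of 10 min, tested at 0.1 uM; a higher number here means faster removal of the compound, a lower number slower removal:
Compound 1 `O=C(NCCCCn1cccn1)c1cccc(C2SCC(=O)N2c2ccccn2)c1` gives 304 mL.min-1.g-1
Compound 2 `O=C(NCCCCc1ccccc1)c1cccc(C2SCC(=O)N2c2ccccn2)c1` gives 644 mL.min-1.g-1

Of these two compounds, compound 1 has the lower number and so shows the slower removal in this assay. The next compound, compound 3 `O=C(NCCCCn1cccn1)c1cccc(C2SCC(=O)N2c2cc(F)ccn2)c1`, changes compound 1 at one place (fluoro in place of hydrogen on an aromatic carbon): fluoro in place of hydrogen on an aromatic carbon, turning pyridin-2-yl into 4-fluoropyridin-2-yl. Among the measured compounds shown here, only one measured step is available (a 2.1-fold higher number from compound 1 to compound 2 (0.33 log units; beyond the scatter)). It is modest and beyond the scatter, but it swaps 1H-pyrazol-1-yl for phenyl on the chain and leaves the pyridin-2-yl group untouched, so it bears on this change only as a rough guide to how far one substitution can move the number. For the measured compounds named here, no measured compound carries fluoro, so no direction can be supported and no step beyond the scatter is expected in this assay. The expected change is small (a 1.0-fold lower number from compound 1 to compound 3 (0.02 log units; within the scatter)). Compound 3 is estimated at 290 mL.min-1.g-1, with an expected range from 160 mL.min-1.g-1 to 520 mL.min-1.g-1.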

Compound 3, intrinsic clearance in microsomes: 397 mL.min-1.g-1
Estimate against measurement, compound 3: 1.4-fold (0.14 log units) below; measured number inside the range.
By their numbers in this assay, from the lowest: compounds 1, 3 and 2 (each within the scatter of the next, the first and the last beyond it).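

In this assay, the change from pyridin-2-yl to 4-fluoropyridin-2-yl gives a step that stays inside the usual scatter (a 1.3-fold higher number from compound 1 to compound 3 (0.12 log units; within the scatter)), so compound 3 cannot be told apart from compound 1. Among the compounds shown here, this is the first view of the aromatic carbon opposite the ring nitrogen: the earlier step, at the end of the chain (a 2.1-fold higher number from compound 1 to compound 2 (0.33 log units; beyond the scatter)), lay beyond the scatter, whereas fluoro in place of hydrogen here does not. Nothing available accounts for this result at this position.

On these data alone, whether another group on this carbon, such as chloro, methoxy or a dimethylamino group, would move the number beyond the scatter remains open. Also open, as far as these compounds go, is whether the same fluoro, placed on compound 2 with its phenyl-ended chain, would give a similar step.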